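The source may report more compounds than this note shows. Statements on the series, on what has been measured and on what is new or still open speak of the compounds shown alone.

Series notes. In an assay on isolated protein for inhibition of Long-chain-fatty-acid--CoA ligase 1 (Homo sapiens), read by mass spectrometry, with a stated time of 90 min, in the presence of a further agent that is not named here (on this read-out lower numbers stand for stronger inhibition and higher numbers for weaker inhibition), compound 1 `Cc1cccc(Cc2nc3cc(O[C@H]4CC[C@@H](C(=O)O)CC4)ccc3n2C)c1` gives 42 nM, the highest of the two numbers recorded so far. Its nearest neighbour is compound 2 `Cc1cccc(Cc2nc3cc(O[C@H]4CC[C@@H](C(=O)O)CC4)cc(Cl)c3n2C)c1`, which in this assay gives 28 nM; the step of a 1.5-fold lower number from compound 1 to compound 2 (0.18 log units; within the scatter) is within the scatter.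

Compound 3 `Cc1cccc(Cc2nc3cc(O[C@H]4CC[C@@H](c5noc(=O)[nH]5)CC4)ccc3n2C)c1` has not yet been measured in this assay. It differs from compound 1 by a group of 6 heavy atoms (2 carbon, 2 nitrogen, 2 oxygen; one five-membered aromatic ring with 3 hetero atoms) in place of a group of 3 heavy atoms (1 carbon, 2 oxygen; no ring), on a saturated ring carbon. Among the compounds with values here, the only measured step, the one from compound 1 to compound 2, concerns a chloro on an aromatic carbon of the shared core and so does not bear on an exchange at the saturated ring; no measured pair tells how this assay answers a change at that position. With nothing to point either way, the expectation for compound 3 is a step of a 1.2-fold higher number from compound 1 to compound 3 (0.08 log units; within the scatter), within the scatter, with a wide band of uncertainty. Compound 3 is estimated at 50 nM, within a range of 12 nM to 250 nM.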

Compound 3, half-maximal inhibitory concentration: 47 nM
Beside the measured number, compound 3's estimate is 1.1-fold (0.03 log units) above it; low and high end bracket the measured number.
By their numbers in this assay, from the lowest: compounds 2, 1 and 3 (each within the scatter of the next).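

In this assay, within the data shown here, the exchange of the carboxy for the five-membered aromatic ring with 3 hetero atoms on the saturated ring carbon gives a 1.1-fold higher number from compound 1 to compound 3 (0.05 log units; within the scatter), the first measured exchange at this position. The carboxy is therefore not needed for a number of this size in this series, since a larger ring group with 1 hydrogen-bond donor and 3 hydrogen-bond acceptors reads the same within the scatter. No supporting measurement bears on why the two groups read alike.

From the compounds shown here alone, a single exchange does not define the tolerance of this position, and how an amine or a primary amide on the same saturated ring carbon would read remains open. Also open, going by these compounds, is whether the chloro of compound 2 and the ring group of compound 3 would combine on the shared core.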